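Removing the chloro from compound 2

The source may hold more compounds than are shown below. What is called first, only, known or untested is meant among the compounds shown, and "the series" means these compounds.

In a functional assay on UACC-257 cells (Homo sapiens) for inhibition, read by sulforhodamine B assay, with a stated time of 48 h, tested at 10 uM (a higher number here means more inhibition of growth at the concentration tested, a lower number less inhibition of growth), compound 2 `Clc1ccc(-c2cn3nc(-c4ccccc4)nc3s2)cc1` gives 15% and compound 3 `COc1ccc(-c2nc3sc(-c4ccc(Cl)cc4)cn3n2)cc1` gives 15.4%, so the two sit level: a number 0.4 percentage points higher from compound 2 to compound 3 (within the scatter). Compound 1 `COc1ccc(-c2nc3sc(-c4ccccc4)cn3n2)cc1` stands higher at 28%.

Compound 4 `c1ccc(-c2nc3sc(-c4ccccc4)cn3n2)cc1` differs from compound 2 by hydrogen in place of chloro on an aromatic carbon, with hydrogen in place of chloro on an aromatic carbon. Among the compounds with values here, the one measured chloro change runs the opposite way, chloro in place of hydrogen: a number 12.6 percentage points lower from compound 1 to compound 3 (beyond the scatter). Methoxy in place of hydrogen showed no step beyond the scatter, so compound 4 is expected near compound 1. Reversing the chloro change gives an expected rise of similar size, a number 11 percentage points higher from compound 2 to compound 4 (beyond the scatter). The estimate for compound 4 is 26% (range 15% to 37%).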

Compound 4, percent growth inhibition at one concentration: 13%
Beside the measured number, compound 4's estimate is 13 percentage points above it; the whole stated range lies above it.
By their numbers in this assay, from the lowest: compounds 4, 2 and 3 (each within the scatter of the next); then compound 1.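

In this assay, hydrogen in place of chloro on this aromatic carbon gives a number 2 percentage points lower from compound 2 to compound 4 (within the scatter), so the clear chloro step seen with the methoxy group present does not carry over to its absence: the same change on two cores in this assay, a number 12.6 percentage points lower (beyond the scatter) from compound 1 to compound 3 and a number 2 percentage points higher (within the scatter) from compound 4 to compound 2, 14.6 percentage points apart, beyond the scatter of two such steps

Hydrogen in place of methoxy gives a number 15 percentage points lower from compound 1 to compound 4 (beyond the scatter), so the methoxy step likewise depends on whether the chloro is present: the same change on two cores in this assay, a number 0.4 percentage points higher (within the scatter) from compound 2 to compound 3 and a number 15 percentage points higher (beyond the scatter) from compound 4 to compound 1, 14.6 percentage points apart, beyond the scatter of two such steps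

Only compound 1, with methoxy and without chloro, stands clear of the others.

As far as these compounds go, whether an amine or a carboxylic acid at this position, in place of the chloro, would give a number above that of compound 1 stays open.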